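A few compounds are considered here, and "the series" means these few. Any claim that something is new, unique, unknown or untested is made for them only; others in the source may bear on it.

Measured compounds in an assay on CHO cells for antagonist activity at transient receptor potential cation channel subfamily V member 1 (Homo sapiens), read by FLIPR and calcium flux; on this read-out higher numbers stand for weaker inhibition and lower numbers for stronger inhibition:
- compound 1, `CC(C(=O)NCc1ccc(C(F)(F)F)nc1C1CCC(F)(F)CC1)c1ccc(NS(C)(=O)=O)c(F)c1`, gives 1.5 nM
- compound 2, `C[C@H](C(=O)NCc1ccc(C(F)(F)F)nc1C1=CCC(C(C)(C)C)CC1)c1ccc(NS(C)(=O)=O)c(F)c1`, gives 0.1 nM
- compound 3, `C[C@H](C(=O)NCc1ccc(C(F)(F)F)nc1C1=CCC(C)(C)CC1)c1ccc(NS(C)(=O)=O)c(F)c1`, gives 0.1 nM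

Among these three, compound 1 stands highest in this assay; compounds 2 and 3 both sit clearly lower, beyond the scatter, so compound 1 is the weakest inhibitor of the set. Compound 4, `CCC/C=C/c1nc(C(F)(F)F)ccc1CNC(=O)C(C)c1ccc(NS(C)(=O)=O)c(F)c1`, has not yet been measured. It differs from compound 1 in one place: pent-1-en-1-yl in place of 4,4-difluorocyclohexyl on an aromatic carbon. Within the data shown here, only one measured step touches the same aromatic carbon: no change at the digits printed from compound 2 to compound 3 (within the scatter), where swapping one ring for another left the number unchanged. That step, and the gap between compound 1 and compounds 2 and 3, show that the group at this carbon can matter, but neither involves replacing a ring by an open chain, so the direction is uncertain. A modest step upward, possibly within the scatter, is expected: a 2.0-fold higher number from compound 1 to compound 4 (0.30 log units; within the scatter). Compound 4 is therefore estimated at 3 nM, within a range of 0.8 nM to 12 nM.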

Compound 4, inhibition constant: 0.9 nM
The estimate for compound 4 lay 3.3-fold (0.52 log units) above the measured number; measured number inside the range.
By their numbers in this assay, from the lowest: compounds 2 and 3 (each within the scatter of the next); then compounds 4 and 1 (each within the scatter of the next).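

In this assay, the open chain pent-1-en-1-yl can take the place of the 4,4-difluorocyclohexyl ring on this aromatic carbon next to the ring nitrogen (a 1.7-fold lower number from compound 1 to compound 4 (0.22 log units; within the scatter)), a change that stays within the scatter. Among these compounds, the one earlier step at this carbon only exchanged one ring for another, whereas this step shows that neither a ring nor the fluorine atoms are required here for a number in this range. Nothing shown explains why the number holds up when the ring is lost.

From the compounds shown here alone, what a saturated pentyl chain would give remains open, so the role of the double bond in pent-1-en-1-yl is unsettled. Also open, going by these compounds, is how a longer chain or an amine at this carbon would behave.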